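Chloro for trifluoromethyl on a diarylurea pyrazole

The compounds below may be only part of what the source reports. "The series", "measured", "known", "first", "only" and "open" are said of these compounds alone.

Measured compounds:
compound 1 `O=C(Nc1cccc(-n2cc(-c3ccncc3)c(-c3cc(O)cc(Cl)c3)n2)c1)Nc1ccc(Cl)c(Cl)c1`, in a functional assay on CCRF-CEM cells (Homo sapiens) for inhibition, read by sulforhodamine B assay, with a stated time of 48 h, tested at 0.01 uM (a lower number here means a stronger effect, a higher number a weaker effect of the compound at the concentration tested), compound 1 gives 96%
compound 2 `COc1cc(Cl)cc(-c2nn(-c3cccc(NC(=O)Nc4ccc(Cl)c(C(F)(F)F)c4)c3)cc2-c2ccncc2)c1`, in this assay compound 2 gives 97%

Compound 2 stands highest of the two numbers in this assay, but its nearest neighbour, compound 1, lies within the scatter of it, so the two cannot be told apart and neither is called weaker or stronger. Both numbers sit near the top of the scale, so at this concentration each compound leaves the cells largely unaffected.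

Compound 3 `COc1cc(Cl)cc(-c2nn(-c3cccc(NC(=O)Nc4ccc(Cl)c(Cl)c4)c3)cc2-c2ccncc2)c1` is not yet measured. It differs from compound 2 in one place: chloro in place of trifluoromethyl on an aromatic carbon. Compound 1 already carries the 3,4-dichlorophenyl on its urea, with a different group on the other aryl ring, and gives a number within the scatter of compound 2.

Among the compounds with values here, no step between measured compounds is available. In this assay the expected step from compound 2 to compound 3 is a number 1 percentage points lower from compound 2 to compound 3 (within the scatter), that is, none beyond the scatter, because compound 1 with 96% shows the 3,4-dichlorophenyl urea at the same level. Compound 3 is therefore estimated at 96%, with a range from 88% to 101%.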

Compound 3, a percentage reported as activity, at one concentration (the size of the read-out at that concentration, not a potency): 97%
Compound 3: middle estimate off by 1 percentage points, on the low side; the range from low to high includes it.
By their numbers in this assay, from the lowest: compounds 1, 2 and 3 (each within the scatter of the next).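

In this assay, within the data shown here, chloro in place of trifluoromethyl on the aromatic carbon gives no change at the digits printed from compound 2 to compound 3 (within the scatter), which is the first direct reading of this change at this position. Compound 3 also links the two earlier compounds through a second single change, methyl in place of hydrogen on an oxygen on an aromatic ring, which gives a number 1 percentage points higher from compound 1 to compound 3 (within the scatter); neither change therefore separates its pair at the concentration tested, and all three compounds sit near the top of the scale. No measurement is available here that would account for these readings.

Since all three numbers lie so near the top of the scale, the compounds shown leave open whether either change would matter at a concentration where the cells respond more clearly. They also leave open how an amine or a nitrile on the same aromatic carbon would read, and whether a longer chain on the oxygen would fall within the scatter of compound 3.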